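Trading 3-fluorophenyl for 4-methylbenzyl on the amide nitrogen

The source may hold more compounds than are shown below. What is called first, only, known or untested is meant among the compounds shown, and "the series" means these compounds.

Compound 1 (`C=C(Br)C(=O)Nc1cccc(/C=C/C(=O)Nc2cccc3ccccc23)c1`) and compound 2 (`C=C(Br)C(=O)Nc1cccc(/C=C/C(=O)Nc2cccc(F)c2)c1`) share one core and carry different groups on the amide-type nitrogen. In a functional assay on MCF7 cells (Homo sapiens) for inhibition, read by MTT assay, with a stated time of 72 h (on this read-out higher numbers stand for weaker inhibition and lower numbers for stronger inhibition), compound 1 reads 2800 nM while compound 2 reads 3300 nM and the two numbers lie within the usual scatter of each other, so compound 2 stands level with compound 1.

Compound 3 (`C=C(Br)C(=O)Nc1cccc(/C=C/C(=O)NCc2ccc(C)cc2)c1`) has 4-methylbenzyl in place of 3-fluorophenyl on an amide-type nitrogen, and its value is not yet known. Going by the values given here, no measured pair shows this exact change. Among the compounds with values here, with compound 1 at 2800 nM and compound 2 at 3300 nM as the only guide, a step beyond the scatter in this assay is not expected in either direction. The estimated step (a 1.1-fold higher number from compound 2 to compound 3 (0.03 log units; within the scatter)) is therefore small. For compound 3 the estimated value is 3500 nM (range 1300 nM to 9000 nM).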

Compound 3, half-maximal inhibitory concentration: 2200 nM
For compound 3 the middle estimate is 1.6-fold (0.20 log units) above the measured one, within the range that was stated.
By their numbers in this assay, from the lowest: compounds 3, 1 and 2 (each within the scatter of the next).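

Going by these compounds alone, putting 4-methylbenzyl in place of 3-fluorophenyl on the amide-type nitrogen gives the first measured single change at this position, and in this assay it amounts to a 1.5-fold lower number from compound 2 to compound 3 (0.18 log units; within the scatter) within the usual scatter. The nitrogen can therefore carry either group without a difference that this assay can separate from repeat-to-repeat variation, even though the fluorine leaves and the entering group holds only carbon. No measurement is at hand that would explain this result. As far as these compounds go, what remains open is whether any group on this nitrogen can move the reading beyond the scatter at all, as each of the three compounds carries an aromatic ring there. A simple chain ending in an amine or a carboxylic acid would put a very different kind of group at this place, and its effect cannot be judged from these compounds.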